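The compounds below may be only part of what the source reports. "The series", "measured", "known", "first", "only" and "open" are said of these compounds alone.

In an assay on isolated protein for inhibition of serine/threonine-protein kinase PAK 1 (Homo sapiens), read by ADP-Glo, with a stated time of 40 min (a higher number here means a weaker inhibitor, a lower number a stronger inhibitor), compound 1 `O=C(NC1CCN(c2ncnc3[nH]ncc23)CC1)c1ccccc1Cl` gives 5240 nM, and compound 2 `COc1ccc(NC(=O)NC2CCN(c3ncnc4[nH]ncc34)CC2)cc1` gives 6370 nM; compound 2 therefore holds the highest of the two numbers, with compound 1 nearest. Among the compounds with values here, the one step in hand, a 1.2-fold higher number from compound 1 to compound 2 (0.08 log units; within the scatter), swapped both the linking group and the aryl ring at once. Compound 3 `O=C(Nc1ccccc1Cl)NC1CCN(c2ncnc3[nH]ncc23)CC1` differs from compound 2 only in the aryl ring: 2-chlorophenyl in place of 4-methoxyphenyl on an amide-type nitrogen. Since the earlier step barely moved the number in this assay, compound 3 is expected to sit close to compound 2, at about 5500 nM, with a likely range of 2500 nM to 12000 nM. This expectation amounts to a 1.2-fold lower number from compound 2 to compound 3 (0.06 log units; within the scatter).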

Compound 3, half-maximal inhibitory concentration: 560 nM
The estimate for compound 3 lay 9.8-fold (0.99 log units) above the measured number, and the stated range ends above it.
By their numbers in this assay, from the lowest: compound 3; then compounds 1 and 2 (each within the scatter of the next).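

In this assay the aryl group on the amide-type nitrogen clearly matters: 2-chlorophenyl in place of 4-methoxyphenyl gives an 11-fold lower number from compound 2 to compound 3 (1.06 log units; beyond the scatter) with the rest of the molecule unchanged. The link matters too, as (2-chlorophenyl)amino in place of 2-chlorophenyl on a carbonyl carbon gives a 9.4-fold lower number from compound 1 to compound 3 (0.97 log units; beyond the scatter) and so the two changes offset each other in the earlier combined step. Nothing available here explains these gains. Still open, on these data alone, is whether the gain follows the chlorine or its ring position, which plain phenyl, 4-chlorophenyl or 2-methoxyphenyl on this nitrogen could separate.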